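Adding (methylsulfamoyl)amino to the benzyl series

The source may report more compounds than this note shows. Statements on the series, on what has been measured and on what is new or still open speak of the compounds shown alone.

Values measured in an ADME assay on HUVEC cells (Homo sapiens) for cytotoxicity, read by MTT assay, with a stated time of 48 h (a higher number here means a weaker inhibitor, a lower number a stronger inhibitor), so far
compound 1 `Cc1c(Cc2ccccc2)c(=O)oc2cc(OCCOc3no[n+]([O-])c3S(=O)(=O)c3ccccc3)ccc12` gives 440 nM
compound 2 `COc1cc(OCCOc2no[n+]([O-])c2S(=O)(=O)c2ccccc2)ccc1C(=O)/C=C/c1ccccc1` gives 410 nM
compound 3 `Cc1c(Cc2ccc(F)cc2)c(=O)oc2cc(OCCOc3no[n+]([O-])c3S(=O)(=O)c3ccccc3)ccc12` gives 270 nM

In this assay the value of compound 1 (440 nM) lies within the scatter of the values of compound 2 and compound 3, so no order is drawn among these three.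

The next comparison is with compound 4 `CNS(=O)(=O)Nc1cccc(Cc2c(C)c3ccc(OCCOc4no[n+]([O-])c4S(=O)(=O)c4ccccc4)cc3oc2=O)c1`, which differs from compound 1 in one place ((methylsulfamoyl)amino in place of hydrogen on an aromatic carbon) and has (methylsulfamoyl)amino in place of hydrogen on an aromatic carbon. The new group stands on a six-membered aromatic ring of carbon only, meta to a large group.

Going by the values given here, only one measured step bears on this change. It is a 1.6-fold lower number from compound 1 to compound 3 (0.21 log units; within the scatter) for fluoro in place of hydrogen on an aromatic carbon, and it stays within the scatter. Among the compounds with values here, that step involves a different group, and no measured compound carries (methylsulfamoyl)amino, so the evidence is thin. No step beyond the scatter is expected, and no direction can be firmly assigned. The expected change is a 1.5-fold lower number from compound 1 to compound 4 (0.17 log units; within the scatter) and remains only an estimate. The range is kept wide for that reason. For compound 4 the estimated value is 300 nM, with an expected range from 100 nM to 800 nM in this assay when measured.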

Compound 4, half-maximal inhibitory concentration: 190 nM
Beside the measured number, compound 4's estimate is 1.6-fold (0.20 log units) above it; low and high end bracket the measured number.
By their numbers in this assay, from the lowest: compounds 4, 3, 2 and 1 (each within the scatter of the next, the first and the last beyond it).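

In this assay, going by these compounds alone, (methylsulfamoyl)amino on a six-membered aromatic ring of carbon only, meta to a large group, gives a 2.3-fold lower number from compound 1 to compound 4 (0.36 log units; beyond the scatter), a modest change but the only single-place step so far that passes the scatter, and this ring carries the much larger group with no rise in the number. Set against the fluoro analogue, the step reads a 1.4-fold lower number from compound 3 to compound 4 (0.15 log units; within the scatter), which stays within the scatter, so the 3-((methylsulfamoyl)amino)phenyl and 4-fluorophenyl variants are not separated in this assay, and the step from compound 1 is the only firm reading for the new group. No measurement at hand accounts for the lower number of compound 4 relative to compound 1.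

Open, from the compounds shown here alone, is whether the step belongs to the whole (methylsulfamoyl)amino group or would also appear with a simple amine, a carboxylic acid or a methoxy group at the same place on the ring. Also open, going by these compounds, is whether (methylsulfamoyl)amino gives a similar step at another place on this ring, or on the phenyl ring of compound 2.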